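Urea aryl swap on the propyl-linked core

This account rests on a few compounds, and the source may have more. Where it says the series, first, only, none or still open, it means among the compounds named here.

Compound 2 `CN(C)CCCn1cnnc1-c1cc(Oc2ccc(NC(=O)Nc3ccccc3C(F)(F)F)cc2F)ccn1` gives 28600 nM in an ADME assay on WI-38 cells (Homo sapiens) for cytotoxicity, read by MTT assay, with a stated time of 72 h; on this read-out lower numbers stand for stronger inhibition and higher numbers for weaker inhibition; of the two numbers seen so far it holds the higher one, the other being compound 1 `CN(C)CCn1cnnc1-c1cc(Oc2ccc(NC(=O)Nc3ccc(F)c(Cl)c3)cc2F)ccn1`, which in this assay gives 7580 nM, a gap beyond the scatter. Compound 3 `CN(C)CCCn1cnnc1-c1cc(Oc2ccc(NC(=O)Nc3ccc(F)c(Cl)c3)cc2F)ccn1` carries 3-chloro-4-fluorophenyl in place of 2-(trifluoromethyl)phenyl on an amide-type nitrogen, the same aryl group found in compound 1. Among the compounds with values here, no step on this change has been measured. The expected step from compound 2 to compound 3, a 2.4-fold lower number from compound 2 to compound 3 (0.38 log units; beyond the scatter), points toward a lower number, roughly a modest decrease because compound 1 with this aryl group gives 7580 nM. Compound 3 is estimated at 12000 nM, within 5000 nM to 30000 nM.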

Compound 3, half-maximal inhibitory concentration: 5370 nM
Beside the measured number, compound 3's estimate is 2.2-fold (0.35 log units) above it; the measured number falls inside the stated range.
By their numbers in this assay, from the lowest: compounds 3 and 1 (each within the scatter of the next); then compound 2.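

In this assay, 3-chloro-4-fluorophenyl in place of 2-(trifluoromethyl)phenyl on an amide-type nitrogen gives a 5.3-fold lower number from compound 2 to compound 3 (0.73 log units; beyond the scatter) and shows, with the chain held constant, that this position affects the read-out. With 3-chloro-4-fluorophenyl held constant, (dimethylamino)methyl in place of dimethylamino gives a 1.4-fold lower number from compound 1 to compound 3 (0.15 log units; within the scatter) and does not separate the two compounds. Nothing on hand explains either result. Still open, as far as these compounds go, is whether the chain change would also leave the read-out unmoved with 2-(trifluoromethyl)phenyl on the amide-type nitrogen. Also open, from the compounds shown here alone, is how a longer chain or a morpholine in place of dimethylamino would read here.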